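Swapping the Anilino Ring in a Cyanopyrimidine Thioether

A few compounds are considered here, and "the series" means these few. Any claim that something is new, unique, unknown or untested is made for them only; others in the source may bear on it.

Compound 1 `C#CCSc1nc(Nc2ccccc2Cl)c(C#N)c(-c2ccccc2)n1` gives > 128000 nM
Compound 2 `N#Cc1c(Nc2cccc(Cl)c2)nc(SCc2cn(Cc3ccccc3Cl)nn2)nc1-c1ccccc1` gives 24400 nM

Of the compounds shown here, two have been measured in a functional assay on ECa-109 cells (Homo sapiens) for inhibition, read by MTT assay, with a stated time of 72 h; a higher number here means a weaker inhibitor, a lower number a stronger inhibitor. The value for compound 1 is a limit of the assay, not a number, and it is the only limit among the two results, (the limit of > 128000 nM in this assay, at which 1 of the 2 values shown sits). Among the measured compounds shown here, compound 2 is therefore the only compound with a measured number, 24400 nM, and there is no second number to compare it with; compound 1 and compound 2 also differ in more than one place, so no single step between them can be read.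

Compound 3 `N#Cc1c(Nc2ccccc2F)nc(SCc2cn(Cc3ccccc3Cl)nn2)nc1-c1ccccc1` is not yet measured. It differs from compound 2 in one place: 2-fluorophenyl in place of 3-chlorophenyl on a nitrogen on an aromatic ring. For the measured compounds named here, with no measured step of this kind to lean on, the expectation rests only on the number for compound 2. A step from compound 2 to compound 3 of modest size, toward weaker inhibition, is expected, a 1.6-fold higher number from compound 2 to compound 3 (0.21 log units; within the scatter), though the change could also fall within the scatter. Compound 3 is estimated at 40000 nM, with a likely range from 12000 nM to 128000 nM.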

Compound 3, half-maximal inhibitory concentration: 23000 nM
Compound 3: middle estimate off by 1.7-fold (0.24 log units), on the high side; the measured number falls inside the stated range.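

In this assay, putting 2-fluorophenyl in place of 3-chlorophenyl on a nitrogen on an aromatic ring gives a 1.1-fold lower number from compound 2 to compound 3 (0.03 log units; within the scatter), so this read-out cannot tell the two compounds apart. Among the compounds shown here, this is the first step at this position that can be read, as compound 1 and compound 2 differ in more than one place, and it shows that the number of compound 2 does not depend on having a 3-chlorophenyl group here: a ring with a different halogen, placed differently, serves as well in this one pair. Nothing in the data bears on why the two compounds read alike.

This one swap alters both the halogen and where it sits on the ring, so the pair cannot show whether each change alone would do nothing or whether two separate effects happen to cancel. It also leaves open how far this tolerance reaches, for example whether a plain phenyl, or a ring carrying a carboxylic acid or an amine, would read the same on that nitrogen.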